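Ethyl for methylsulfanyl on the aryl ring of compound 1

This account rests on a few compounds, and the source may have more. Where it says the series, first, only, none or still open, it means among the compounds named here.

Measured compounds:
compound 1, `CSc1ccc(N(C)c2ncnc3occ(C)c23)cc1`, 12.3 nM
compound 2, `CCCN(c1ccc(OC)cc1)c1ncnc2occ(C)c12`, 27.3 nM
compound 3, `COc1ccc(N(c2ncnc3occ(C)c23)C(C)C)cc1`, 504 nM

In a functional assay on MDA-MB-435 cells (Homo sapiens) for inhibition, read by sulforhodamine B assay, with a stated time of 48 h (a higher number here means that more compound is needed for the effect, a lower number that less compound is needed), compound 1 holds the lowest number of the three; compound 2 is nearest to it, and compound 3 is furthest. Among the compounds with values here, the one step among measured compounds, an 18-fold higher number from compound 2 to compound 3 (1.27 log units; beyond the scatter), concerns the group on the nitrogen, not the aryl ring. Compound 4, `CCc1ccc(N(C)c2ncnc3occ(C)c23)cc1`, differs from compound 1 only at the aryl ring: ethyl in place of methylsulfanyl on an aromatic carbon, on an aromatic carbon of a six-membered aromatic ring of carbon only, para to a large group. Within the data shown here, no measured step bears on this exchange, so a step of no more than the scatter is expected, in either direction. Compound 4 is therefore estimated at 20 nM, between 6 nM and 65 nM, a step of a 1.6-fold higher number from compound 1 to compound 4 (0.21 log units; within the scatter) expected.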

Compound 4, half-maximal effective concentration: 183 nM
Compound 4: the middle estimate sits 9.2-fold (0.96 log units) below what was measured; measured number above the stated range.
By their numbers in this assay, from the lowest: compound 1; then compound 2; then compound 4; then compound 3.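

In this assay, within the data shown here, the step of a 15-fold higher number from compound 1 to compound 4 (1.17 log units; beyond the scatter) is the first large change seen at the aryl ring rather than at the group on the nitrogen. This position, para to a large group, therefore does not tolerate every exchange, even though methylsulfanyl and ethyl have the same count of heavy atoms. The exchange replaces sulfur with carbon and removes the one hydrogen-bond acceptor counted in methylsulfanyl, but no evidence is available to explain the step. The compounds shown leave open how an amine, a hydroxyl or a longer chain would behave at this position.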